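A few compounds are considered here, and "the series" means these few. Any claim that something is new, unique, unknown or untested is made for them only; others in the source may bear on it.

Measured so far:
compound 1, `CCCCc1cnc(C(CC)Cc2ccc(-c3ccccc3C(=O)O)cc2)[nH]1`: 2720 nM
compound 2, `O=C(O)c1ccccc1-c1ccc(CCc2ncc(-c3ccccc3)[nH]2)cc1`: 4950 nM

Both were run in an in vitro functional assay on cells for agonist activity at Bombesin receptor subtype-3 (Homo sapiens), read by luminescence and calcium flux; a lower number here means that less compound is needed, a higher number that more compound is needed for the effect. Compound 2 has the higher of the two numbers, but against compound 1 the gap lies within the scatter, so the two are not separated on this read-out.

Compound 3, `N#Cc1ccc(Cc2cnc(CCc3ccc(-c4ccccc4C(=O)O)cc3)[nH]2)cc1`, is not yet measured. It differs from compound 2 in one place: 4-cyanobenzyl in place of phenyl on an aromatic carbon. Going by the values given here, no pair of measured compounds shows what such a change does here, so there is no step to lean on.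

Compound 3 is expected to sit close to compound 2, with a step of a 1.4-fold lower number from compound 2 to compound 3 (0.15 log units; within the scatter) that is not expected to exceed the scatter. The estimated value for compound 3 is 3500 nM, within a range from 1000 nM to 12000 nM.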

Compound 3, half-maximal effective concentration: 5890 nM
Compound 3: the middle estimate sits 1.7-fold (0.23 log units) below what was measured; the range from low to high includes it.
By their numbers in this assay, from the lowest: compounds 1, 2 and 3 (each within the scatter of the next, the first and the last beyond it).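

In this assay, 4-cyanobenzyl in place of phenyl on this aromatic carbon gives a 1.2-fold higher number from compound 2 to compound 3 (0.08 log units; within the scatter) and so leaves compound 2 and compound 3 unseparated. Going by these compounds alone, this is the first step that can be read at this position, and it shows that the position accepts this exchange of a ring-bearing group, with its added nitrile, without a change beyond the scatter. No measurement at hand explains this result.

On these data alone, it remains open whether an amine, a carboxylic acid or a simple longer alkyl chain on this carbon would separate from compound 2. A single step also leaves open how other groups behave here.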